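The source may report more compounds than this note shows. Statements on the series, on what has been measured and on what is new or still open speak of the compounds shown alone.

Compound 1 `NC[C@@H]1CCCc2cc(S(=O)(=O)c3cccc(F)c3)ccc21` is the stronger of the two measured compounds: in an assay on isolated protein for displacement of a labelled ligand from 5-hydroxytryptamine receptor 6 (Homo sapiens) (a higher number here means a weaker inhibitor, a lower number a stronger inhibitor), compound 1 gives 0.0794 nM, the lowest of the two numbers recorded. Compound 2 `NC[C@@H]1CCCc2cc(S(=O)(=O)c3cn[nH]c3)ccc21` differs only at the sulfonyl sulfur and in this assay compound 2 gives 2 nM, so that a 25-fold higher number from compound 1 to compound 2 (1.40 log units; beyond the scatter). That step shows how sharply this assay responds to a change on the sulfonyl side of the shared core.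

Compound 3 `O=S(=O)(c1cccc(F)c1)c1ccc2c(c1)CCC[C@H]2CN1CC(O)C1` has not yet been measured. It keeps the 3-fluorophenyl of compound 1 and changes the other end: 3-hydroxyazetidin-1-yl in place of amino on a saturated chain carbon bound to a saturated ring carbon. Among the measured compounds shown here, the only measured step concerns the sulfonyl substituent and leaves the amino group untouched, so it gives no direct guide to a change at the saturated chain carbon. For the measured compounds named here, with no measured step covering this position, the expectation rests on the size of the change alone, a small ring in place of a single nitrogen, and a modest weakening is estimated, so that a 3.8-fold higher number from compound 1 to compound 3 (0.58 log units; beyond the scatter). Compound 3 is therefore estimated at 0.3 nM, within a range from 0.08 nM to 1.5 nM.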

Compound 3, inhibition constant: 0.1 nM
Estimate against measurement, compound 3: 3.0-fold (0.48 log units) above; measured number inside the range.
By their numbers in this assay, from the lowest: compounds 1 and 3 (each within the scatter of the next); then compound 2.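

At the saturated chain carbon bound to a saturated ring carbon, putting 3-hydroxyazetidin-1-yl in place of the amino group in this assay gives a 1.3-fold higher number from compound 1 to compound 3 (0.10 log units; within the scatter), even though the group grows from 1 heavy atom to 5 heavy atoms and brings in a four-membered non-aromatic ring. This place therefore behaves very differently from the sulfonyl side of the shared core, where a single swap gave a 25-fold higher number from compound 1 to compound 2 (1.40 log units; beyond the scatter), so a large change in the group need not mean a large change in the number. No information is available on why these two numbers lie so close.

As far as these compounds go, it remains open which part of the new group matters: azetidin-1-yl without its hydroxyl, dimethylamino or piperidin-1-yl at the same place would show how far this tolerance reaches and whether the hydroxyl contributes at all. From the compounds shown here alone, it is also open whether a carboxylic acid would be accepted here, and whether 3-hydroxyazetidin-1-yl would behave the same way when paired with the 1H-pyrazol-4-yl of compound 2.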